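The compounds below may be only part of what the source reports. "The series", "measured", "known", "first", "only" and "open" are said of these compounds alone.

The shared core, seen in compound 1 `COC(=O)c1cccn1-c1ccc(Nc2ncc(Cl)c(Nc3ccccc3NS(C)(=O)=O)n2)c(OC)c1`, carries a methoxy group on a carbonyl carbon, and in a functional assay on A549 cells (Homo sapiens) for antiproliferative activity, read by MTT assay, with a stated time of 72 h (on this read-out higher numbers stand for weaker inhibition and lower numbers for stronger inhibition), compound 1 gives 2510 nM. Compound 2 `COc1cc(-n2cccc2C(=O)N2CCCCC2)ccc1Nc1ncc(Cl)c(Nc2ccccc2NS(C)(=O)=O)n1` has piperidin-1-yl in place of that methoxy. In this assay compound 2 reaches only a limit of the assay, > 10000 nM. Compound 3 `CCN1CCN(C(=O)c2cccn2-c2ccc(Nc3ncc(Cl)c(Nc4ccccc4NS(C)(=O)=O)n3)c(OC)c2)CC1` carries 4-ethylpiperazin-1-yl on the same carbonyl carbon. In this assay compound 3 likewise gives a limit, > 10000 nM. Both exchanges of the methoxy weaken inhibition: an at least 3.9-fold higher number from compound 1 to compound 2 (0.60 log units; beyond the scatter) and an at least 3.9-fold higher number from compound 1 to compound 3 (0.60 log units; beyond the scatter). The comparison a step that the two limits leave unreadable from compound 2 to compound 3, since both ends sit at the limit of > 10000 nM in this assay, at which 2 of the 3 values shown sit.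

Compound 4 `COc1cc(-n2cccc2C(=O)N2CCC(C)CC2)ccc1Nc1ncc(Cl)c(Nc2ccccc2NS(C)(=O)=O)n1` differs from compound 2 by methyl in place of hydrogen on a saturated ring carbon. For the measured compounds named here, this is a smaller change than any measured step, all of which exchanged the whole group on the carbonyl carbon; none touched a saturated ring carbon of the piperidin-1-yl, so no measured step bears closely on it. Compound 2 already stands at the limit, and the two measured enlargements of the group on the carbonyl carbon both raised the number beyond the scatter. A single methyl is therefore expected to leave compound 4 at or beyond that limit, with an expected step that the limit leaves unreadable from compound 2 to compound 4 of no readable size. The estimated value for compound 4 in this assay is 15000 nM, within a range from 5000 nM to 50000 nM.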

Compound 4, half-maximal inhibitory concentration: 2200 nM
Beside the measured number, compound 4's estimate is 6.8-fold (0.83 log units) above it; measured number below the stated range.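

In this assay, the position three ring bonds from the ring nitrogen of the piperidin-1-yl turns out to be highly sensitive, as methyl in place of hydrogen on this saturated ring carbon gives an at least 4.5-fold lower number from compound 2 to compound 4 (0.65 log units; beyond the scatter). Enlarging the group on the carbonyl carbon therefore does not always cost activity: compound 4 goes against the trend set by compound 2 and compound 3, with 4-methylpiperidin-1-yl in place of 4-ethylpiperazin-1-yl giving an at least 4.5-fold lower number from compound 3 to compound 4 (0.65 log units; beyond the scatter), and 4-methylpiperidin-1-yl in place of methoxy giving a 1.1-fold lower number from compound 1 to compound 4 (0.06 log units; within the scatter), so the bulkier group matches the methoxy of compound 1 within the scatter. The true size of the two steps from compound 2 and compound 3 remains open, since each starts from a limit of the assay: the limit of > 10000 nM in this assay, at which 2 of the 4 values shown sit.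

The compounds shown do not tell whether this effect is specific to methyl, or whether an ethyl, a hydroxyl or an amine on the same ring carbon would serve equally. They also leave open whether a methyl on another ring carbon of the piperidin-1-yl would have the same effect, and whether a smaller ring such as pyrrolidine would respond in the same way.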